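Swapping ethynyl for cyano at a measurement limit

The source may hold more compounds than are shown below. What is called first, only, known or untested is meant among the compounds shown, and "the series" means these compounds.

Measured in a functional assay on KB cells (Homo sapiens) for cytotoxicity; a lower number here means a stronger inhibitor, a higher number a weaker inhibitor:
- compound 1 `C=C[C@]1(CO)O[C@@H](n2ccc(N)nc2=O)C[C@@H]1O`: > 350000 nM
- compound 2 `CC[C@]1(CO)O[C@@H](n2ccc(N)nc2=O)C[C@@H]1O`: > 350000 nM
- compound 3 `C#C[C@]1(CO)O[C@@H](n2ccc(=O)[nH]c2=O)[C@H](O)[C@@H]1O`: > 350000 nM

Each of these entries is a limit and not a number. Compound 3 stands at > 350000 nM, so it has a limit rather than a measured potency. For the measured compounds named here, it shares this position with the other two compounds, as the series so far shows (the limit of > 350000 nM in this assay, at which 3 of the 3 values shown sit).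

Compound 4 `N#C[C@]1(CO)O[C@@H](n2ccc(=O)[nH]c2=O)[C@H](O)[C@@H]1O` has cyano in place of ethynyl on a saturated ring carbon. The two groups are counted alike except for the hydrogen-bond acceptor that cyano brings.

Going by the values given here, only one measured step offers a comparison, ethyl in place of vinyl on a saturated ring carbon. That step, a step that the two limits leave unreadable from compound 1 to compound 2, gives no size to carry over. The data therefore offer no sign that this kind of exchange moves a compound in this assay, and no direction can be expected with confidence. The most likely result is that compound 4 also stays at the limit, with no readable step.

The expected change is a number no higher from compound 3 to compound 4 (the limit leaves the size open). Compound 4 is estimated at 350000 nM, within an expected range from 150000 nM to 500000 nM.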

Compound 4, half-maximal inhibitory concentration: > 350000 nM
Compound 4 was reported as a limit; the forecaster's own chance of this, stated with the estimate: 85%; the middle value sits exactly at the limit.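

For the compounds shown here, compound 3 and compound 4 are both reported in this assay as limits and not as numbers, so the exchange of ethynyl for cyano gives no step that can be read. All the compounds shown sit together: the limit of > 350000 nM in this assay, at which 4 of the 4 values shown sit. On these data alone, what stays open is whether cyano and ethynyl differ at all, and which change to the shared core would give a measurable potency.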